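The source may report more compounds than this note shows. Statements on the series, on what has been measured and on what is new or still open speak of the compounds shown alone.

Compound 1 `CC(C)n1cnc2c(Nc3ccccc3)nc(NCOCc3ccc(C(=O)Nc4ccccc4N)cc3)nc21` gives 6.58% in a functional assay on HepG2 cells (Homo sapiens) for antiproliferative activity, read by CCK-8 assay, with a stated time of 72 h, tested at 2 uM; on this read-out lower numbers stand for a weaker effect and higher numbers for a stronger effect at the one concentration tested.
Compound 2 `Nc1ccccc1NC(=O)c1ccc(COCNc2nc(Nc3ccccc3)c3ncn(C4CCCC4)c3n2)cc1` gives 37.5% in this assay.
Compound 3 `CCCCn1cnc2c(Nc3ccccc3)nc(NCOCc3ccc(C(=O)Nc4ccccc4N)cc3)nc21` gives 46.6% in this assay.

Among these three numbers compound 2 stands second highest. Its nearest neighbour is compound 3, and that step, a number 9.1 percentage points higher from compound 2 to compound 3 (within the scatter), lies within the scatter, so the two cannot be ordered. Its furthest neighbour is compound 1, and the step of a number 30.9 percentage points higher from compound 1 to compound 2 (beyond the scatter) lies beyond the scatter.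

Compound 4 `Nc1ccccc1NC(=O)c1ccc(COCNc2nc(Nc3ccc(-c4ccccc4)cc3)c3ncn(C4CCCC4)c3n2)cc1` differs from compound 2 in one place: phenyl in place of hydrogen on an aromatic carbon. The new group sits on an aromatic carbon of a six-membered aromatic ring of carbon only, para to a large group; cut one bond further out, the change reads phenyl to 4-phenylphenyl.

For the measured compounds named here, none of the measured steps touches that ring. The three steps, a number 30.9 percentage points higher from compound 1 to compound 2 (beyond the scatter), a number 40 percentage points higher from compound 1 to compound 3 (beyond the scatter) and a number 9.1 percentage points higher from compound 2 to compound 3 (within the scatter), all concern the group on the aromatic nitrogen of the shared core, and each exchanges one group for another there. They therefore say nothing direct about what a phenyl entering at this position does, and the expectation for compound 4 can rest only on the value of compound 2 itself.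

Given that, no step beyond the scatter is expected; the estimated step is a number 2.5 percentage points higher from compound 2 to compound 4 (within the scatter). Compound 4 is estimated at 40%, with a range from 15% to 65%.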

Compound 4, a percentage reported as inhibition, at one concentration (the size of the read-out at that concentration, not a potency): 4.85%
Beside the measured number, compound 4's estimate is 35.2 percentage points above it; the measured number lies below the stated range.
By their numbers in this assay, from the lowest: compounds 4 and 1 (each within the scatter of the next); then compounds 2 and 3 (each within the scatter of the next).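

The earlier compounds shown here varied only the group on the aromatic nitrogen of the shared core, so compound 4 gives the first sign that the phenyl ring outside that site also affects the read-out in this assay. Changing phenyl to 4-phenylphenyl, with the new phenyl para to a large group, gives a number 32.7 percentage points lower from compound 2 to compound 4 (beyond the scatter), a large step beyond the scatter, which shows that this position does not tolerate every addition at the one concentration tested. No measurement offered here accounts for the loss, and the size of the step is all that can be stated.

The compounds shown do not tell whether the fall belongs to phenyl in particular or would also follow from another group at this position, such as fluorine, methoxy or an amine. They also leave open whether the same phenyl would bring a step of similar size when butyl rather than cyclopentyl sits on the aromatic nitrogen.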